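Ring Methyl on Two Related Cores in a Mouse Assay

This account rests on a few compounds, and the source may have more. Where it says the series, first, only, none or still open, it means among the compounds named here.

Compound 1, `CC(=O)N(C)CC#CCn1ccnc1`: 0.97 mg/kg
Compound 2, `CC(=O)N(C)CC#CCn1cncc1C`: 5.4 mg/kg
Compound 3, `COC(=O)N(C)C(C)C#CCn1ccnc1`: 6.6 mg/kg

In a functional assay on the whole organism for agonist activity, with Mus musculus as the target (a higher number here means that more compound is needed for the effect, a lower number that less compound is needed), compound 1 gives 0.97 mg/kg, compound 2 gives 5.4 mg/kg, and compound 3 gives 6.6 mg/kg. Compound 2 differs from compound 1 by methyl in place of hydrogen on an aromatic carbon and that step is a 5.6-fold higher number from compound 1 to compound 2 (0.75 log units; beyond the scatter). Compound 4, `COC(=O)N(C)C(C)C#CCn1cncc1C`, has not yet been measured; it differs from compound 3 by methyl in place of hydrogen on an aromatic carbon. The two changes are the same kind of change, though the ring atom that bears a group of 9 heavy atoms in the first pair bears a large group in the second. The difference between the two cores is not broken down here. For compound 4 the step in this assay is expected to be a 4.5-fold higher number from compound 3 to compound 4 (0.66 log units; beyond the scatter), which rests on a 5.6-fold higher number from compound 1 to compound 2 (0.75 log units; beyond the scatter). Compound 4 is therefore estimated at 30 mg/kg, somewhere between 10 mg/kg and 90 mg/kg.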

Compound 4, dose for half-maximal effect: 97 mg/kg
Compound 4: the middle estimate sits 3.2-fold (0.51 log units) below what was measured, and the stated range ends below it.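

In this assay, methyl in place of hydrogen on an aromatic carbon gave a 15-fold higher number from compound 3 to compound 4 (1.17 log units; beyond the scatter) and so raised the number on this core as well. Set beside the earlier step, the change carried over in direction, and the two sizes cannot be told apart: the same change on two cores in this assay, a 5.6-fold higher number (0.75 log units; beyond the scatter) from compound 1 to compound 2 and a 15-fold higher number (1.17 log units; beyond the scatter) from compound 3 to compound 4, 2.6-fold (0.42 log units) apart, within the scatter of two such steps. Within the data shown here, this rests on only two pairs in one assay, so it does not show that the step would hold on any other core, and it gives no reason for the rise.

The compounds shown leave open whether an ethyl group or a chlorine atom in place of the methyl would give a similar step. They also leave open how the methyl step would run on a core with an amine in place of the carbonyl-bearing group.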